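The source may hold more compounds than are shown below. What is called first, only, known or untested is meant among the compounds shown, and "the series" means these compounds.

Measured compounds in a functional assay on MCF7 cells (Homo sapiens) for antiproliferative activity; on this read-out higher numbers stand for weaker inhibition and lower numbers for stronger inhibition:
Compound 1 `CC(=O)Oc1ccc2cc(-n3cc(-c4ccccc4)nn3)c(=O)oc2c1C` gives 40800 nM.
Compound 2 `COc1ccc(-c2cn(-c3cc4ccc(OC(C)=O)c(C)c4oc3=O)nn2)cc1` reaches only the limit of the assay, > 100000 nM.
Compound 3 `CC(=O)Oc1ccc2cc(-n3cc(-c4cc5ccccc5[nH]4)nn3)c(=O)oc2c1C` gives 76100 nM.

Compound 3 and compound 1 sit within the scatter of each other, as a 1.9-fold higher number from compound 1 to compound 3 (0.27 log units; within the scatter) shows; the third value belongs to compound 2 and is a limit, (the limit of > 100000 nM in this assay, at which 1 of the 3 values shown sits), so no number can be compared with it. Across the whole set, then, compound 3 stands beside compound 1 and is not separated from it.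

Compound 4 `CC(=O)Oc1ccc2cc(-n3cc(-c4c[nH]c5ccccc45)nn3)c(=O)oc2c1C` differs from compound 3 by 1H-indol-3-yl in place of 1H-indol-2-yl on an aromatic carbon. Among the compounds with values here, two measured steps touch the same position: a 1.9-fold higher number from compound 1 to compound 3 (0.27 log units; within the scatter), within the scatter, and an at least 1.3-fold lower number from compound 2 to compound 3 (0.11 log units; that floor lies within the scatter), whose floor also lies within the scatter. Within the data shown here, neither of them shifts the point of attachment of the indole, so no measured step speaks directly to the change from compound 3 to compound 4. What the measured steps do show is that changes of the aryl group at this position have moved the read-out little, apart from the methoxy step an at least 2.4-fold higher number from compound 1 to compound 2 (0.38 log units; beyond the scatter). On that basis a step within the scatter is expected in this assay, a 1.1-fold higher number from compound 3 to compound 4 (0.02 log units; within the scatter). Compound 4 is therefore estimated at 80000 nM, with a range from 30000 nM to 200000 nM.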

Compound 4, half-maximal inhibitory concentration: 7450 nM
The estimate for compound 4 lay 11-fold (1.03 log units) above the measured number; measured number below the stated range.
By their numbers in this assay, from the lowest: compound 4; then compounds 1 and 3 (each within the scatter of the next). At a limit, above all of these: compound 2.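

In this assay, within the data shown here, the point of attachment of the indole on the five-membered aromatic ring with 3 nitrogen turns out to matter, which the earlier steps could not show: with the same atoms joined differently, the change gives a 10-fold lower number from compound 3 to compound 4 (1.01 log units; beyond the scatter). This position is also more responsive than the earlier aryl changes suggested, as 1H-indol-3-yl stands clear of the simple aryl groups, with a 5.5-fold lower number from compound 1 to compound 4 (0.74 log units; beyond the scatter) and an at least 13-fold lower number from compound 2 to compound 4 (1.12 log units; beyond the scatter), the latter being only a floor, while compound 3 shows that an indole alone does not bring this gain. Compound 2 stands at a limit: the limit of > 100000 nM in this assay, at which 1 of the 4 values shown sits.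

Still open, going by these compounds, is whether the hydrogen on the indole nitrogen contributes to the stronger read-out of compound 4, a question that a methyl group on that nitrogen would test. Also open, on these data alone, is whether the effect of 1H-indol-3-yl carries over when the acetate ester on the shared core gives way to a free hydroxyl or an amide.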